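Swapping the ring on the thiocarbonyl of compound 2

This account rests on a few compounds, and the source may have more. Where it says the series, first, only, none or still open, it means among the compounds named here.

Measured compounds:
compound 1 `N/C(=N\NC(=S)N1CCOCC1)c1ccccn1` 81.6%
compound 2 `Cc1cccc(/C(N)=N/NC(=S)N2CCOCC2)n1` 74.7%

In a functional assay on MCF7 cells (Homo sapiens) for cytotoxicity, read by MTT assay, with a stated time of 72 h, tested at 100 uM (on this read-out higher numbers stand for more inhibition of growth at the one concentration tested and lower numbers for less inhibition of growth), compound 2 gives 74.7%, the lowest of the two numbers recorded, and its nearest neighbour is compound 1 with 81.6%. Among the compounds with values here, the one measured step, a number 6.9 percentage points lower from compound 1 to compound 2 (within the scatter), lies within the scatter, so the two compounds cannot be ordered on this read-out.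

Compound 3 `Cc1cccc(/C(N)=N/NC(=S)N2CCCC2)n1` is not yet measured. It differs from compound 2 by pyrrolidin-1-yl in place of morpholin-4-yl on a thiocarbonyl carbon. Within the data shown here, no measured step touches the ring on the thiocarbonyl carbon; the only step recorded, a number 6.9 percentage points lower from compound 1 to compound 2 (within the scatter), concerns a methyl on the shared core and is within the scatter. There is therefore no basis in the numbers for expecting a change beyond the scatter in this assay in either direction, and the uncertainty is correspondingly wide.

Compound 3 is estimated to give 72% in this assay, within a range of 50% to 88%. This estimate means a step of a number 2.7 percentage points lower from compound 2 to compound 3 (within the scatter), which is expected to lie within the scatter.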

Compound 3, percent growth inhibition at one concentration: 61.8%
Beside the measured number, compound 3's estimate is 10.2 percentage points above it, and the stated range covers the measured number.
By their numbers in this assay, from the lowest: compound 3; then compounds 2 and 1 (each within the scatter of the next).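

In this assay, the ring on the thiocarbonyl carbon turns out to be a place where a single exchange can register: pyrrolidin-1-yl in place of morpholin-4-yl gives a step of a number 12.9 percentage points lower from compound 2 to compound 3 (beyond the scatter). Within the data shown here, the only earlier step, the methyl in place of hydrogen on an aromatic carbon, was a number 6.9 percentage points lower from compound 1 to compound 2 (within the scatter), so this is the first change to separate two compounds on this read-out. Nothing available bears on what lies behind the step.

The exchange alters the ring size and removes the ring oxygen together, and the compounds shown do not separate the two; a piperidin-1-yl group on the same thiocarbonyl carbon, a six-membered ring without the oxygen, would do so. Also open, going by these compounds, is whether an open-chain dimethylamino group at this place would fall with either ring, and whether the same pyrrolidin-1-yl for morpholin-4-yl exchange on the core of compound 1, which lacks the methyl, would give a step of similar size.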